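This account rests on a few compounds, and the source may have more. Where it says the series, first, only, none or still open, it means among the compounds named here.

Compound 1, with the structure `NS(=O)(=O)c1ccc(N2N=C(c3ccccc3)CC2c2ccccc2F)cc1`, was tested in an ADME assay on BHK-21 cells (Mesocricetus auratus) for cytotoxicity, read by MTT assay, with a stated time of 72 h (on this read-out higher numbers stand for lower toxicity in this test and lower numbers for higher toxicity in this test), and gives 21000 nM. Compound 2, `Cc1cccc(C2CC(c3ccccc3)=NN2c2ccc(S(N)(=O)=O)cc2)c1`, differs from it by 3-methylphenyl in place of 2-fluorophenyl on a saturated ring carbon and in this assay compound 2 gives 25000 nM, a step of a 1.2-fold higher number from compound 1 to compound 2 (0.08 log units; within the scatter). Compound 3, `NS(=O)(=O)c1ccc(N2N=C(c3ccc(OCc4ccccc4)cc3)CC2c2ccccc2F)cc1`, shares the core of compound 1 except for (benzyloxy in place of hydrogen on an aromatic carbon); in this assay compound 3 gives 90000 nM, which is a 4.3-fold higher number from compound 1 to compound 3 (0.63 log units; beyond the scatter) and leaves compound 3 with the highest number of the three measured compounds.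

Compound 4, `Cc1cccc(C2CC(c3ccc(OCc4ccccc4)cc3)=NN2c2ccc(S(N)(=O)=O)cc2)c1`, is not yet measured. It differs from compound 3 by 3-methylphenyl in place of 2-fluorophenyl on a saturated ring carbon. Going by the values given here, this is the same kind of change as the one from compound 1 to compound 2, although the surroundings are described differently: in compound 3 the place is next to the ring atom that bears a 4-sulfamoylphenyl group and two ring bonds from the ring atom that bears a large group, whereas in compound 1 it is next to the ring atom that bears a large group and two ring bonds from the ring atom that bears a phenyl group. Because the earlier step of a 1.2-fold higher number from compound 1 to compound 2 (0.08 log units; within the scatter) stayed within the scatter, the step from compound 3 to compound 4 is expected to be about a 1.1-fold higher number from compound 3 to compound 4 (0.05 log units; within the scatter). Compound 4 is therefore estimated to give about 100000 nM in this assay, expected to lie between 45000 nM and 220000 nM.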

Compound 4, half-maximal cytotoxic concentration: 8000 nM
For compound 4 the middle estimate is 13-fold (1.10 log units) above the measured one; the whole stated range lies above it.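

The swap of 2-fluorophenyl for 3-methylphenyl does not carry over unchanged between cores in this assay: with the benzyloxy group present it gives an 11-fold lower number from compound 3 to compound 4 (1.05 log units; beyond the scatter), which means more toxicity in this test, and the two cores clearly part ways: the same change on two cores in this assay, a 1.2-fold higher number (0.08 log units; within the scatter) from compound 1 to compound 2 and an 11-fold lower number (1.05 log units; beyond the scatter) from compound 3 to compound 4, 13-fold (1.13 log units) apart, beyond the scatter of two such steps

Read the other way round, the benzyloxy change also depends on its partner, giving a 3.1-fold lower number from compound 2 to compound 4 (0.49 log units; beyond the scatter), against a rise on the core of compound 1: the same change on two cores in this assay, a 4.3-fold higher number (0.63 log units; beyond the scatter) from compound 1 to compound 3 and a 3.1-fold lower number (0.49 log units; beyond the scatter) from compound 2 to compound 4, 13-fold (1.13 log units) apart, beyond the scatter of two such steps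

Both comparisons rest on the same four compounds and are one finding seen from two sides, which shows that the two changes do not simply add up here but does not show why, or how widely this holds in the series.

The compounds shown leave open whether a methoxy or hydroxyl group in place of benzyloxy would depend on its partner in the same way. They also leave open whether a chlorophenyl group in place of 2-fluorophenyl or 3-methylphenyl would follow compound 3 or compound 4.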